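Diethylamino for methyl on the trifluoromethoxy analogue

A few compounds are considered here, and "the series" means these few. Any claim that something is new, unique, unknown or untested is made for them only; others in the source may bear on it.

Compound 3 `Cc1ccc2nc(-c3ccccc3OC(F)(F)F)[nH]c(=O)c2c1` gives 66.9% in an assay on isolated protein for inhibition of DNA topoisomerase 1 (Homo sapiens), with a stated time of 30 min, tested at 100 uM; a higher number here means a stronger effect of the compound at the concentration tested, a lower number a weaker effect. Compound 1 `Cc1ccc2nc(-c3ccccc3C(F)(F)F)[nH]c(=O)c2c1` gives 72%; the step of a number 5.1 percentage points lower from compound 1 to compound 3 (within the scatter) is within the scatter, so these two cannot be ranked against each other. Compound 2 `CCN(CC)c1ccc2nc(-c3ccccc3N(C)C)[nH]c(=O)c2c1` gives 82.1%, beyond the scatter above compound 3, which therefore sits at the lower end of the three. Compound 4 `CCN(CC)c1ccc2nc(-c3ccccc3OC(F)(F)F)[nH]c(=O)c2c1` differs from compound 3 by diethylamino in place of methyl on an aromatic carbon. Going by the values given here, no measured step isolates this change: compound 2 carries diethylamino but differs from compound 3 in a second place as well, so its higher value cannot be assigned to the diethylamino alone. Among the compounds with values here, the only single-change step, a number 5.1 percentage points lower from compound 1 to compound 3 (within the scatter), concerns a different part of the molecule and is within the scatter. A modest rise is expected, a number 9.1 percentage points higher from compound 3 to compound 4 (within the scatter), not certainly beyond the scatter. Compound 4 is estimated at 76%, range 58% to 90%.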

Compound 4, a percentage reported as inhibition, at one concentration (the size of the read-out at that concentration, not a potency): 81.2%
Estimate against measurement, compound 4: 5.2 percentage points below; low and high end bracket the measured number.
By their numbers in this assay, from the lowest: compounds 3, 1, 4 and 2 (each within the scatter of the next, the first and the last beyond it).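

In this assay, going by these compounds alone, the step of a number 14.3 percentage points higher from compound 3 to compound 4 (beyond the scatter) gives the first single-change reading for diethylamino in place of methyl at this position of the shared core. With diethylamino held fixed, the step of a number 0.9 percentage points lower from compound 2 to compound 4 (within the scatter) shows that trifluoromethoxy in place of dimethylamino does not separate these two compounds. No evidence on the origin of either step is available.

Going by these compounds, it remains open whether a cyclic amine such as morpholine or pyrrolidine at this position would give a similar value. On these data alone, it also remains open whether the diethylamino step would recur with trifluoromethyl in place of trifluoromethoxy.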